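From methoxymethyl to chloro: one swap, one open number

This account rests on a few compounds, and the source may have more. Where it says the series, first, only, none or still open, it means among the compounds named here.

Of the compounds shown here, three have been measured so far. In a physicochemical assay for lipophilicity, at pH 7.4 (on this read-out lower numbers stand for lower lipophilicity and higher numbers for higher lipophilicity), compound 1 (`COCc1ccccc1C1Cc2nccn2C1`) stands lowest of the three at 1.8 and lies beyond the scatter from both of the others. Compound 2 (`COc1cccc(C2CCc3nc[nH]c3C2)c1`) reads 2.6 and compound 3 (`COc1ccccc1C1CCc2nc[nH]c2C1`) reads 2.8 and these two lie within the scatter of each other. Both differ from compound 1 in more than one place, so their gaps cannot be credited to any single group.

Compound 4 (`Clc1ccccc1C1Cc2nccn2C1`) has not yet been measured. For the measured compounds named here, it keeps the core of compound 1 and carries chloro in place of methoxymethyl on an aromatic carbon as its only change. Going by the values given here, no measured pair shows this exchange, so the expectation rests on the structural change alone, and a rise beyond the scatter is expected in this assay for this swap. The estimated size of that rise is a number 0.80 log units higher from compound 1 to compound 4 (beyond the scatter) and it remains a judgement. Such a rise would stay within the span already seen, since compound 3 reaches 2.8 in this small set. For compound 4 the expected value is 2.6 with an estimated range from 2.1 to 3.1 around it.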

Compound 4, distribution coefficient: 2.6
Beside the measured number, compound 4's estimate shows no gap at the digits printed; low and high end bracket the measured number.
By their numbers in this assay, from the lowest: compound 1; then compounds 2, 4 and 3 (each within the scatter of the next).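

In this assay, chloro in place of methoxymethyl, on an aromatic carbon ortho to a group of 8 heavy atoms, gives a number 0.80 log units higher from compound 1 to compound 4 (beyond the scatter). For the compounds shown here, this is the first step in the set that changes only one place, so this gap, unlike the earlier gaps from compound 1, can be tied to a single exchange on the shared core. The exchange replaces a chain of 3 heavy atoms, including 1 hydrogen-bond acceptor, with a single chlorine atom that has no hydrogen-bond acceptor, but no measurement here tells which feature of this exchange accounts for the rise.

This single pair cannot show whether the size of the step is specific to chloro, and the compounds shown leave open how fluoro, methyl, an amine or a carboxylic acid would read at this same place. They also leave open whether the same exchange would give a similar step at another aromatic carbon or on a different core, since one pair at one place cannot establish a general rule.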